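The source may report more compounds than this note shows. Statements on the series, on what has been measured and on what is new or still open speak of the compounds shown alone.

Compound 1 `Nc1nc2c(s1)C[C@@H](NC(=O)c1cc(Br)c[nH]1)CC2` is the starting point for this step. In an assay with sodium channel protein type 4 subunit alpha (Homo sapiens) as the target, read by patch clamp (on this read-out higher numbers stand for weaker inhibition and lower numbers for stronger inhibition), compound 1 gives > 30000 nM. That reading is a limit of the assay rather than a number, so the standing of compound 1 is known only as a boundary (the limit of > 30000 nM in this assay, at which 1 of the 2 values shown sits). Compound 2 `Nc1nc2c(s1)C[C@@H](NC(=O)c1cc(Br)c(Br)[nH]1)CC2` differs from compound 1 by bromo in place of hydrogen on an aromatic carbon; in this assay compound 2 gives 15000 nM, which is an at least 2.0-fold lower number from compound 1 to compound 2 (0.30 log units; that floor lies within the scatter). Compound 3 `Cn1cccc1C(=O)N[C@H]1CCc2nc(N)sc2C1` goes the other way: 1-methyl-1H-pyrrol-2-yl in place of 4-bromo-1H-pyrrol-2-yl on a carbonyl carbon. Among the compounds with values here, the single measured step adds bromine and gave the floor-level gain just noted, whereas the change to compound 3 removes the bromine and brings in the 1-methyl-1H-pyrrol-2-yl group, a direction no measured pair covers. No step beyond the scatter is expected in this assay, and with compound 1 at the limit (the limit of > 30000 nM in this assay, at which 1 of the 2 values shown sits), compound 3 is expected at or past it. The estimate for compound 3 is 50000 nM, between 20000 nM and 150000 nM. This estimate means an expected step that the limit leaves unreadable from compound 1 to compound 3.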

Compound 3, half-maximal inhibitory concentration: 16000 nM
For compound 3 the middle estimate is 3.1-fold (0.49 log units) above the measured one; measured number below the stated range.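

In this assay, the change on the carbonyl carbon from 4-bromo-1H-pyrrol-2-yl to 1-methyl-1H-pyrrol-2-yl gives an at least 1.8-fold lower number from compound 1 to compound 3 (0.27 log units; that floor lies within the scatter). The earlier step only added a second bromine, whereas compound 3 shows that a numeric reading is also obtained at this position with no bromine at all and with no hydrogen-bond donor counted on the entering group. The real size of the step stays unreadable, as compound 1 is held only as a limit of the assay: the limit of > 30000 nM in this assay, at which 1 of the 3 values shown sits.

Which part of the change carries the step, the 1-methyl or the loss of the 4-bromo, remains open. Also open, going by these compounds, is how a plain 1H-pyrrol-2-yl, or a different group on the carbonyl carbon such as a carboxylic acid or an amine-bearing chain, would read.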